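The source may report more compounds than this note shows. Statements on the series, on what has been measured and on what is new or still open speak of the compounds shown alone.

Measured so far in an ADME assay on microsomes from liver (Rattus norvegicus) for metabolic stability; a lower number here means that the compound disappears faster, a higher number that the compound lasts longer:
- compound 1 `CC(C)C(c1ccc(-c2ccc3cccc(F)c3c2)[nH]c1=O)N1CCCCC1=O`: 0.102 h
- compound 2 `Cc1c[nH]c(C(c2ccc(-c3ccc4cccc(F)c4c3)[nH]c2=O)C(C)C)n1`: < 0.0667 h

Compound 2 stands at < 0.0667 h, which is a limit of the assay and not a number. Compound 3 `CC(C)C(/C=C1\CCNC1=O)c1ccc(-c2ccc3cccc(F)c3c2)[nH]c1=O` differs from it on a saturated chain carbon bound to an aromatic carbon and a saturated chain carbon: a group of 7 heavy atoms (5 carbon, 1 nitrogen, 1 oxygen; one five-membered non-aromatic ring with 1 hetero atom) in place of a group of 6 heavy atoms (4 carbon, 2 nitrogen; one five-membered aromatic ring with 2 hetero atoms), on a saturated chain carbon bound to an aromatic carbon and a saturated chain carbon. The 4-methyl-1H-imidazol-2-yl group leaves, and a five-membered non-aromatic ring enters. Among the measured compounds shown here, only one measured step bears on this place, an at least 1.5-fold lower number from compound 1 to compound 2 (0.18 log units; that floor lies within the scatter), and its floor lies within the scatter. Compound 1, with its 2-oxopiperidin-1-yl group, gives 0.102 h, so a number close to that of compound 1 seems likely. No step beyond the scatter is expected in this assay, and any small move should be toward a longer half-life. The expected step is an at least 1.3-fold higher number from compound 2 to compound 3 (0.13 log units; that floor lies within the scatter). For compound 3 the estimated half-life is 0.09 h, with an expected range of 0.05 h to 0.18 h.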

Compound 3, half-life: 0.345 h
The estimate for compound 3 lay 3.8-fold (0.58 log units) below the measured number; measured number above the stated range.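

In this assay, compound 3 shows that this place on a saturated chain carbon can shift the half-life beyond the scatter, with an at least 5.1-fold higher number from compound 2 to compound 3 (0.71 log units; beyond the scatter). That step starts from compound 2, whose value is a limit of the assay and not a number: the limit of < 0.0667 h in this assay, at which 1 of the 3 values shown sits. The clearer comparison is a 3.4-fold higher number from compound 1 to compound 3 (0.53 log units; beyond the scatter), where the leaving 2-oxopiperidin-1-yl group and the entering group have the same count of heavy atoms, so that count alone does not set the half-life in this pair.

The compounds shown leave open whether the longer half-life goes with the five-membered ring or with the double bonds outside aromatic rings. Also open, going by these compounds, is how an amine, a carboxylic acid or a longer chain at this place would behave in this assay.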